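The compounds below may be only part of what the source reports. "The series", "measured", "known", "first", "only" and "open" are said of these compounds alone.

Compound 3 `COc1ccc(C(=O)/C=C/c2cc(-c3cc(OC)c(OC)c(OC)c3)n[nH]2)cc1` stands only at a limit in a functional assay on RPMI-8226 cells (Homo sapiens) for inhibition, read by sulforhodamine B assay, with a stated time of 48 h (a higher number here means that more compound is tolerated, a lower number that less compound is tolerated), where compound 3 gives > 100000 nM. Compound 1 `COc1cc(-c2cc(/C=C/C(=O)c3ccc(Cl)c(Cl)c3)[nH]n2)cc(OC)c1OC` likewise gives a limit of > 100000 nM in this assay. Compound 2 `COc1ccc(C(=O)/C=C/c2cc(-c3cc(OC)c(OC)c(OC)c3)n[nH]2)cc1OC` also gives a limit of > 100000 nM. In short, (the limit of > 100000 nM in this assay, at which 3 of the 3 values shown sit). Compound 4 `COc1cc(-c2cc(/C=C/C(=O)c3ccc(F)c(F)c3)[nH]n2)cc(OC)c1OC` differs from compound 3 by 3,4-difluorophenyl in place of 4-methoxyphenyl on a carbonyl carbon. The measured steps that swap the group on that carbonyl carbon, a step that the two limits leave unreadable from compound 1 to compound 2 and a step that the two limits leave unreadable from compound 1 to compound 3, and the smaller step that the two limits leave unreadable from compound 2 to compound 3, are all unreadable; every value involved is a limit. No direction beyond the scatter is therefore expected for a step that the limit leaves unreadable from compound 3 to compound 4. Compound 4 is thus estimated to sit at a limit as well, near 150000 nM with a range from 50000 nM to 500000 nM in this assay.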

Compound 4, concentration lethal to 50% of the cells: > 100000 nM
Compound 4 was reported as a limit; the forecaster's own chance of this, stated with the estimate: 85%; the middle value lies beyond the limit too.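

Compound 4 gives only a limit, > 100000 nM, so its steps from compound 1, compound 2 and compound 3 cannot be read. Whether the group on the carbonyl carbon changes the lethal concentration stays open, because no compound here has an exact value: the limit of > 100000 nM in this assay, at which 4 of the 4 values shown sit.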